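Arylidene variation at the exocyclic double bond: compound 4 outlook

The source may hold more compounds than are shown below. What is called first, only, known or untested is meant among the compounds shown, and "the series" means these compounds.

Measured so far in a functional assay on HepG2 cells (Homo sapiens) for antiproliferative activity, read by MTT assay; a lower number here means a stronger inhibitor, a higher number a weaker inhibitor:
- compound 1, `COc1ccc(/C=C2/SC(N3CCC[C@H]3C(=O)Nc3ccc4ncnc(Nc5cccc(Cl)c5)c4c3)=NC2=O)cc1`: 19000 nM
- compound 2, `O=C1N=C(N2CCC[C@H]2C(=O)Nc2ccc3ncnc(Nc4cccc(Cl)c4)c3c2)S/C1=C/c1ccc(-c2ccccc2)cc1`: 15400 nM
- compound 3, `O=C1N=C(N2CCC[C@H]2C(=O)Nc2ccc3ncnc(Nc4cccc(Cl)c4)c3c2)S/C1=C/c1cccs1`: 4120 nM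

All three share the same core and differ only in the aryl group on the double-bonded chain carbon bound to a double-bonded ring carbon. Compound 2 stands second highest of the three numbers; its nearest neighbour is compound 1, with a 1.2-fold lower number from compound 1 to compound 2 (0.09 log units; within the scatter), and its furthest is compound 3, with a 3.7-fold lower number from compound 2 to compound 3 (0.57 log units; beyond the scatter). The other measured step, a 4.6-fold lower number from compound 1 to compound 3 (0.66 log units; beyond the scatter), points the same way.

The unmeasured compound 4, `O=C1N=C(N2CCC[C@H]2C(=O)Nc2ccc3ncnc(Nc4cccc(Cl)c4)c3c2)S/C1=C/c1ccccc1[N+](=O)[O-]`, differs from compound 2 by 2-nitrophenyl in place of 4-phenylphenyl on a double-bonded chain carbon bound to a double-bonded ring carbon. Among the compounds with values here, no measured step introduces a nitro group, so the only bearing steps are those that exchange one aryl for another at this position. Of these, the replacement of the larger 4-phenylphenyl by a smaller aryl gave a modest lowering in compound 3, while the exchange between compound 1 and compound 2 stayed within the scatter. On that basis a modest lowering, or none beyond the scatter, is expected for compound 4, estimated as a 1.9-fold lower number from compound 2 to compound 4 (0.28 log units; within the scatter). Compound 4 is therefore estimated at 8000 nM in this assay, with a range from 3000 nM to 25000 nM.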

Compound 4, half-maximal inhibitory concentration: 32500 nM
Beside the measured number, compound 4's estimate is 4.1-fold (0.61 log units) below it, and the stated range ends below it.
By their numbers in this assay, from the lowest: compound 3; then compounds 2, 1 and 4 (each within the scatter of the next, the first and the last beyond it).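

In this assay, 2-nitrophenyl in place of 4-phenylphenyl does not repeat the lowering seen with thiophen-2-yl: it gives a 2.1-fold higher number from compound 2 to compound 4 (0.32 log units; beyond the scatter), so fewer heavy atoms on this double-bonded chain carbon do not by themselves bring a lower number. Thiophen-2-yl now stands apart from all three other aryl groups, with a 7.9-fold higher number from compound 3 to compound 4 (0.90 log units; beyond the scatter), and compound 3 is the strongest of the four. Among the groups with six-membered aromatic rings of carbon only, the exchange of 4-methoxyphenyl for 2-nitrophenyl stays within the scatter, at a 1.7-fold higher number from compound 1 to compound 4 (0.23 log units; within the scatter), while compound 2 and compound 4 are separated by a step just beyond it.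

Nothing available explains these differences. Going by these compounds, whether furan-2-yl would follow thiophen-2-yl, and whether an amine in place of the nitro group would change the number, stay open.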